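A side-chain swap with only limits to go on

The source may hold more compounds than are shown below. What is called first, only, known or untested is meant among the compounds shown, and "the series" means these compounds.

Of the compounds shown here, two with a shared core have been tested so far in an ADME assay on MT4 cells (Homo sapiens) for cytotoxicity, read by MTT assay (on this read-out higher numbers stand for lower toxicity in this test and lower numbers for higher toxicity in this test), and neither gives an exact number. Compound 1 (`O=c1cc(Cc2c(F)cccc2F)nc(Sc2ccccc2)[nH]1`) gives > 76000 nM as its result, and this is a limit of the assay. Compound 2 (`O=c1cc(Cc2c(F)cccc2F)nc(SCc2c(F)cccc2F)[nH]1`) stands at > 66000 nM and this too is only a limit.

Compound 3 (`O=c1cc(Cc2c(F)cccc2F)nc(SCCc2ccccc2)[nH]1`) differs from compound 2 by carrying benzyl in place of 2,6-difluorophenyl on a saturated chain carbon bound to a sulfur. For the measured compounds named here, no measured step shows how such a change acts in this assay so the expectation is cautious. The estimate is a step that the limit leaves unreadable from compound 2 to compound 3 and this expected step stays within the usual scatter, favouring neither direction. Compound 3 is expected at 70000 nM with an estimated range from 25000 nM to 150000 nM and may well also return only a limit.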

Compound 3, half-maximal cytotoxic concentration: > 70000 nM
Compound 3: no number, only a limit; the forecaster's own chance of this, stated with the estimate: 75%; the middle value sits exactly at the limit.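

Compound 3 returns only a limit, as do compound 1 and compound 2, so neither step leading to compound 3 can be read. The compounds shown leave open whether changing the group on the sulfur alters the result in this assay at all.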